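Swapping a trifluoromethoxyphenyl arm for a chlorostyryl one

The source may report more compounds than this note shows. Statements on the series, on what has been measured and on what is new or still open speak of the compounds shown alone.

Three measured compounds share one core and differ only in the group attached to a single aromatic carbon. Compound 1 `COC(=O)/C=C/c1cccc(N(Cc2ccc(/C=C/c3cccc(C(F)(F)F)c3)cc2)C(=O)C(C)C)c1` carries a 2-(3-(trifluoromethyl)phenyl)ethenyl arm, and in an assay on isolated protein with Bile acid receptor (Homo sapiens) as the target (a lower number here means that less compound is needed, a higher number that more compound is needed for the effect), compound 1 gives 267 nM. Compound 2 `COC(=O)/C=C/c1cccc(N(Cc2ccc(-c3ccc(OC(F)(F)F)cc3)cc2)C(=O)C(C)C)c1` carries a 4-(trifluoromethoxy)phenyl arm and gives 219 nM. Compound 3 `COC(=O)/C=C/c1cccc(N(Cc2ccc(-c3cccc(OC(F)(F)F)c3)cc2)C(=O)C(C)C)c1` carries a 3-(trifluoromethoxy)phenyl arm and gives 247 nM, the second highest of the three numbers, though all three lie within the usual scatter of one another: a 1.2-fold lower number from compound 1 to compound 2 (0.09 log units; within the scatter) and a 1.1-fold higher number from compound 2 to compound 3 (0.05 log units; within the scatter). Compound 4 `COC(=O)/C=C/c1cccc(N(Cc2ccc(/C=C/c3cccc(Cl)c3)cc2)C(=O)C(C)C)c1` has not yet been measured; its change from compound 3 is 2-(3-chlorophenyl)ethenyl in place of 3-(trifluoromethoxy)phenyl on an aromatic carbon. The step that bears most on this change is a 1.1-fold lower number from compound 1 to compound 3 (0.03 log units; within the scatter), which exchanged an ethenyl-linked aryl arm for a directly attached one and moved the number only within the scatter, as did the other two steps. The step from compound 3 to compound 4 is therefore expected to be small, a 1.0-fold higher number from compound 3 to compound 4 (0.01 log units; within the scatter), with no clear direction. Compound 4 is estimated at 250 nM, within a range from 110 nM to 560 nM.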

Compound 4, half-maximal effective concentration: 164 nM
The estimate for compound 4 lay 1.5-fold (0.18 log units) above the measured number; the measured number falls inside the stated range.
By their numbers in this assay, from the lowest: compounds 4, 2, 3 and 1 (each within the scatter of the next).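

Among the compounds shown here, exchanging trifluoromethyl for chloro on the ethenyl-linked arm, a kind of change the earlier compounds did not include, gives a 1.6-fold lower number from compound 1 to compound 4 (0.21 log units; within the scatter) in this assay, so this substituent can differ without the number leaving the scatter. For the compounds shown here, the exchanges of the whole arm read the same way, with a 1.5-fold lower number from compound 3 to compound 4 (0.18 log units; within the scatter) and a 1.3-fold lower number from compound 2 to compound 4 (0.13 log units; within the scatter), which means that no step among the four arms at this place, para to a large group, goes beyond the scatter. No other data bear on this result.

The compounds shown leave open whether an amine or a carboxylic acid on the arm's aromatic ring would move the number beyond the scatter. They also leave open what a shorter arm, such as a single methyl group, would do at this place.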